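Swapping Chloro for Methyl on a Thiosemicarbazide Amide

The source may report more compounds than this note shows. Statements on the series, on what has been measured and on what is new or still open speak of the compounds shown alone.

Three measured compounds share a core built around a thiosemicarbazide linked to an aromatic amide. Compound 1 `COc1cc2ncnc(NNC(=S)NC(=O)c3ccccc3Cl)c2cc1OC` carries a 2-chlorophenyl group on the amide. In a functional assay on GLC82 cells (Homo sapiens) for cytotoxicity, read by MTT assay, with a stated time of 72 h (on this read-out higher numbers stand for weaker inhibition and lower numbers for stronger inhibition), compound 1 gives 10000 nM. Compound 2 `O=C(NC(=S)NNc1ncnc2ccccc12)c1ccc(C(F)(F)F)cc1` gives 12200 nM in this assay, and compound 3 `Cc1ccccc1C(=O)NC(=S)NNc1ncnc2ccccc12` gives 13200 nM. All three numbers sit within the usual scatter of one another, so on these data compound 1 is simply one of three compounds of closely similar strength, none separated from the others.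

Compound 4 `COc1cc2ncnc(NNC(=S)NC(=O)c3ccccc3C)c2cc1OC` has not yet been measured. It differs from compound 1 in one place: methyl in place of chloro on an aromatic carbon. Within the data shown here, no measured pair shows exactly this change on this core, so there is no step to lean on. Compound 3 carries the same 2-methylphenyl group on a different core and gives 13200 nM, a number close to that of compound 1, which suggests that this methyl does not move the read-out far on its own.

The expectation is therefore a step of a 1.1-fold higher number from compound 1 to compound 4 (0.04 log units; within the scatter), that is, none beyond the scatter. Compound 4 is expected to give about 11000 nM in this assay, most likely between 5000 nM and 25000 nM.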

Compound 4, half-maximal inhibitory concentration: 21500 nM
Compound 4: the middle estimate sits 2.0-fold (0.29 log units) below what was measured; low and high end bracket the measured number.
By their numbers in this assay, from the lowest: compounds 1, 2, 3 and 4 (each within the scatter of the next, the first and the last beyond it).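

On the core of compound 1, exchanging chloro for methyl on an aromatic carbon ortho to a large group gives, in this assay, a 2.2-fold higher number from compound 1 to compound 4 (0.33 log units; beyond the scatter), a modest step towards weaker inhibition. Among these compounds, this shows that the position is not indifferent to the change, even though each group has one heavy atom and neither adds a hydrogen-bond donor or acceptor, a single-place comparison that the earlier compounds, with no step between them, could not offer. Nothing in the data gives a reason for this step.

The compounds shown leave open how a bare hydrogen, a fluoro, a methoxy or an amine on this same aromatic carbon would read in this assay, so one exchange gives a single step and no trend across groups. They also leave open whether exchanging chloro for methyl gives a step of similar size on the core of compound 3, where a 2-chlorophenyl group would provide the matching partner.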